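Chloro added to the trifluoromethylphenyl urea of compound 1

The compounds below may be only part of what the source reports. "The series", "measured", "known", "first", "only" and "open" are said of these compounds alone.

Measured so far:
compound 1, `O=C(Nc1cccc(-n2cc(-c3ccncc3)c(-c3ccc(Cl)c(O)c3)n2)c1)Nc1cccc(C(F)(F)F)c1`, 1340 nM
compound 2, `O=C(Nc1cccc(-n2cc(-c3ccncc3)c(-c3ccc(Cl)c(O)c3)n2)c1)Nc1cc(C(F)(F)F)cc(C(F)(F)F)c1`, 477 nM

Compound 1 gives the highest of the two numbers in a functional assay on RPMI-8226 cells (Homo sapiens) for inhibition, read by sulforhodamine B assay, with a stated time of 48 h; on this read-out lower numbers stand for stronger inhibition of growth and higher numbers for weaker inhibition of growth; its nearest neighbour is compound 2, which lies a 2.8-fold lower number from compound 1 to compound 2 (0.45 log units; beyond the scatter). Going by the values given here, that single step, a trifluoromethyl in place of hydrogen on an aromatic carbon of the terminal phenyl, is the only change on this ring that has been measured, and it was modest but beyond the scatter.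

Compound 3, `O=C(Nc1cccc(-n2cc(-c3ccncc3)c(-c3ccc(Cl)c(O)c3)n2)c1)Nc1ccc(Cl)c(C(F)(F)F)c1`, has not yet been measured in this assay. It differs from compound 1 in one place: chloro in place of hydrogen on an aromatic carbon. Among the compounds with values here, the change sits on the same terminal ring as the step from compound 1 to compound 2, and it adds a single halogen rather than a second trifluoromethyl, so the one relevant precedent points toward a lower number of similar or slightly smaller size. The expected step is therefore a 1.9-fold lower number from compound 1 to compound 3 (0.28 log units; within the scatter), toward stronger growth inhibition, though a result within the scatter of compound 1 would not surprise. Compound 3 is estimated at 700 nM, with a range from 300 nM to 1600 nM.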

Compound 3, concentration for 50% growth inhibition: 580 nM
Beside the measured number, compound 3's estimate is 1.2-fold (0.08 log units) above it, within the range that was stated.
By their numbers in this assay, from the lowest: compounds 2 and 3 (each within the scatter of the next); then compound 1.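

In this assay, the terminal ring takes a chloro ortho to a trifluoromethyl group and para to a large group, and this single added chlorine gives a 2.3-fold lower number from compound 1 to compound 3 (0.36 log units; beyond the scatter). Going by these compounds alone, the earlier pair showed only what a second trifluoromethyl does on this ring, so this is the first sign that a different substituent at a different place on the ring can also lower the number. With a 2.8-fold lower number from compound 1 to compound 2 (0.45 log units; beyond the scatter) beside it, two separate additions to the 3-(trifluoromethyl)phenyl ring now each give a modest step beyond the scatter, and no information available here accounts for either step.

The compounds shown leave open whether the step belongs to chlorine itself or would also appear with another group in the same place, such as fluoro, methyl, methoxy or an amine. They also leave open whether the chloro would lower the number on a ring without the trifluoromethyl group, and whether the same change would carry over to a core lacking the hydroxyl on its chlorophenyl ring.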